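This account rests on a few compounds, and the source may have more. Where it says the series, first, only, none or still open, it means among the compounds named here.

Among the compounds with values here, compound 3 `CCCCOc1ccc([C@@H]2CC[C@H](NC)c3ccccc32)cc1` gives 12500 nM in a functional assay on striatum for inhibition of sodium-dependent dopamine transporter (Rattus norvegicus) (on this read-out lower numbers stand for stronger inhibition and higher numbers for weaker inhibition), the highest of the three numbers measured so far. Its nearest neighbour is compound 1 `CN[C@@H]1CC[C@@H](c2ccc(Oc3ccccc3)cc2)c2ccccc21`, which gives 8400 nM, a gap that lies within the scatter. Compound 2 `CN[C@H]1CC[C@@H](c2ccc(F)cc2)c2ccccc21` gives 4700 nM, and the change from fluoro to butoxy on an aromatic carbon gave a 2.7-fold higher number from compound 2 to compound 3 (0.42 log units; beyond the scatter).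

Compound 4 `CN[C@H]1CC[C@@H](c2ccc(Oc3ccccc3)cc2)c2ccccc21` differs from compound 3 in one place: phenyl in place of butyl on an oxygen on an aromatic ring. Within the data shown here, no measured step between two compounds shows exactly this change, so the only bearing comes from compound 1, which already carries the phenoxy group on the same position but is drawn with a different arrangement at one of its ring carbons; compound 1 gives 8400 nM, and compound 3 gives 12500 nM, two numbers within the scatter of each other. Compound 2 with its fluoro group sits lower, but that change is not the one taken here. The step from compound 3 to compound 4 is therefore expected to be small, most likely a slight move toward lower numbers, estimated as a 1.4-fold lower number from compound 3 to compound 4 (0.14 log units; within the scatter). Compound 4 is accordingly expected to give about 9000 nM in this assay, with a range from 3500 nM to 23000 nM.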

Compound 4, half-maximal inhibitory concentration: 6800 nM
Estimate against measurement, compound 4: 1.3-fold (0.12 log units) above, and the stated range covers the measured number.
By their numbers in this assay, from the lowest: compounds 2, 4, 1 and 3 (each within the scatter of the next, the first and the last beyond it).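

In this assay, phenyl in place of butyl on an oxygen on an aromatic ring gives a 1.8-fold lower number from compound 3 to compound 4 (0.26 log units; within the scatter), so at this position the butoxy and phenoxy groups are not separated beyond the scatter, although the change from fluoro to butoxy had gone beyond it. The change from fluoro to phenoxy gives a 1.4-fold higher number from compound 2 to compound 4 (0.16 log units; within the scatter), so phenoxy, unlike butoxy, stays within the scatter of fluoro, and a larger group on this carbon does not by itself carry the number beyond the scatter. The configuration at the saturated ring carbon likewise shows no effect beyond the scatter, with a 1.2-fold lower number from compound 1 to compound 4 (0.09 log units; within the scatter), and this reading rests on a pair that isolates that one feature: the fact that compounds 1 and 4 differ only in the configuration as drawn.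

The compounds shown leave open how an amine, a carboxylic acid or a shorter methoxy group on this aromatic ring would read in this assay. As far as these compounds go, the other stereocentre is drawn alike in compound 1 and compound 4, so what inverting it would do with the phenoxy group in place also stays open.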